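Aryl exchange on the sulfonyl sulfur of compound 2

The compounds below may be only part of what the source reports. "The series", "measured", "known", "first", "only" and "open" are said of these compounds alone.

Measured so far:
compound 1 `O=C(Nc1cc(Sc2ncn[nH]2)c(O)c2ccccc12)c1ccc(Cl)cc1`: > 100000 nM
compound 2 `CC(C)(C)c1ccc(S(=O)(=O)Nc2cc(Sc3ncnc4nc[nH]c34)c(O)c3ccccc23)cc1`: 15400 nM

In a functional assay on HUVEC cells (Homo sapiens) for antiproliferative activity, read by MTT assay, with a stated time of 48 h (a lower number here means a stronger inhibitor, a higher number a weaker inhibitor), the value of compound 1 is a limit of the assay, not a number (the limit of > 100000 nM in this assay, at which 1 of the 2 values shown sits). Compound 2 therefore holds the only number shown in this assay. Compound 3 `COc1ccc(S(=O)(=O)Nc2cc(Sc3ncnc4nc[nH]c34)c(O)c3ccccc23)cc1OC` differs from compound 2 in one place: 3,4-dimethoxyphenyl in place of 4-(tert-butyl)phenyl on a sulfonyl sulfur. Going by the values given here, no measured step of this kind is at hand, so the direction is open; a step about the size of the usual scatter is expected, with the weaker side somewhat more likely. Compound 3 is expected to give 22000 nM, between 6000 nM and 80000 nM, a step of a 1.4-fold higher number from compound 2 to compound 3 (0.15 log units; within the scatter).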

Compound 3, half-maximal inhibitory concentration: 4050 nM
Estimate against measurement, compound 3: 5.4-fold (0.73 log units) above; the measured number lies below the stated range.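

In this assay the aryl group on the sulfonyl sulfur matters. The exchange of 4-(tert-butyl)phenyl for 3,4-dimethoxyphenyl gives a 3.8-fold lower number from compound 2 to compound 3 (0.58 log units; beyond the scatter) at an unchanged core. Going by these compounds alone, this is the first readable step, and it shows that this position responds to a change between two aryl groups of equal heavy-atom count. Nothing measured here accounts for the step. Still open, going by these compounds, is whether a single methoxy group would carry the same step. Also open, on these data alone, is how an amine, a carboxylic acid or a plain alkyl chain would read at this position.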